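Heptyl in place of 4-bromophenyl in compound 3

The source may hold more compounds than are shown below. What is called first, only, known or untested is meant among the compounds shown, and "the series" means these compounds.

In a functional assay on HeLa cells (Homo sapiens) for inhibition, read by MTT assay, with a stated time of 48 h (on this read-out higher numbers stand for weaker inhibition and lower numbers for stronger inhibition), compound 1 `Brc1ccc(C(c2c[nH]c3ccc(Br)cc23)c2c[nH]c3ccc(Br)cc23)cc1` gives 1500 nM. Compound 2 `O=[N+]([O-])c1ccc2[nH]cc(C(c3ccc(Br)cc3)c3c[nH]c4ccc([N+](=O)[O-])cc34)c2c1` has no exact number, only the limit > 100000 nM. Among the two measured compounds, its reading sits at that limit: the limit of > 100000 nM in this assay, at which 1 of the 2 values shown sits. Compound 3 `CCCCCCCC(c1c[nH]c2ccc([N+](=O)[O-])cc12)c1c[nH]c2ccc([N+](=O)[O-])cc12` differs from compound 2 by having heptyl in place of 4-bromophenyl on a saturated chain carbon bound to two aromatic carbons. In this assay, a modest move toward stronger inhibition is expected, with an estimated at least 2.0-fold lower number from compound 2 to compound 3 (0.30 log units; that floor lies within the scatter). The expected value for compound 3 is 50000 nM, with an estimated range of 15000 nM to 100000 nM.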

Compound 3, half-maximal inhibitory concentration: 35000 nM
Compound 3: the middle estimate sits 1.4-fold (0.15 log units) above what was measured; measured number inside the range.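

In this assay, heptyl in place of 4-bromophenyl on a saturated chain carbon bound to two aromatic carbons gives an at least 2.8-fold lower number from compound 2 to compound 3 (0.45 log units; beyond the scatter), so this position tolerates a chain with no ring and still gives a measurable number. The true size of the step remains unknown because compound 2 has a limit, not a number: the limit of > 100000 nM in this assay, at which 1 of the 3 values shown sits.

The compounds shown leave open whether a shorter chain, a longer chain or an amine at this position would move the reading further. They also leave open whether heptyl would produce a similar step on the core of compound 1.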